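Sulfonyl substituent series: nitro to chloro on the aryl ring

The compounds below may be only part of what the source reports. "The series", "measured", "known", "first", "only" and "open" are said of these compounds alone.

Working notes on the series. Compound 1 `O=C1/C(=C/c2cccnc2)CNC/C1=C\c1ccccc1C(F)(F)F` has the amine nitrogen in the ring unsubstituted; in an ADME assay on L02 cells (Homo sapiens) for cytotoxicity, read by MTT assay, with a stated time of 24 h (on this read-out higher numbers stand for weaker inhibition and lower numbers for stronger inhibition), compound 1 gives 11300 nM. Compound 2 `O=C1/C(=C/c2cccnc2)CN(S(=O)(=O)c2ccccc2)C/C1=C\c1ccccc1C(F)(F)F` carries phenylsulfonyl on that nitrogen, and in this assay compound 2 gives 12500 nM. Compound 3 `O=C1/C(=C/c2cccnc2)CN(S(=O)(=O)c2ccc([N+](=O)[O-])cc2)C/C1=C\c1ccccc1C(F)(F)F` carries (4-nitrophenyl)sulfonyl, and in this assay compound 3 gives 15700 nM, the highest of the three numbers shown, though it is within the scatter of both others: a 1.4-fold higher number from compound 1 to compound 3 (0.14 log units; within the scatter) and a 1.3-fold higher number from compound 2 to compound 3 (0.10 log units; within the scatter), with a 1.1-fold higher number from compound 1 to compound 2 (0.04 log units; within the scatter) for the sulfonyl alone.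

Compound 4 `O=C1/C(=C/c2cccnc2)CN(S(=O)(=O)c2ccc(Cl)cc2)C/C1=C\c1ccccc1C(F)(F)F` is not yet measured. It differs from compound 3 at one place: chloro in place of nitro on an aromatic carbon. The step that bears most closely on it is the one that put nitro on the same aromatic carbon, a 1.3-fold higher number from compound 2 to compound 3 (0.10 log units; within the scatter), which stayed within the scatter, as did every other step in the set. Nothing in these three numbers separates one substituent on this aromatic carbon from another, or from hydrogen. The expectation is therefore no step beyond the scatter, a 1.1-fold lower number from compound 3 to compound 4 (0.05 log units; within the scatter). Compound 4 is estimated at 14000 nM in this assay, with a range from 7000 nM to 28000 nM.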

Compound 4, half-maximal inhibitory concentration: 11900 nM
Beside the measured number, compound 4's estimate is 1.2-fold (0.07 log units) above it; the measured number falls inside the stated range.
By their numbers in this assay, from the lowest: compounds 1, 4, 2 and 3 (each within the scatter of the next).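

With chloro now read on this aromatic carbon, para to a large group, the position has carried nitro, chloro and hydrogen in this assay, and neither new step leaves the scatter: chloro in place of nitro gives a 1.3-fold lower number from compound 3 to compound 4 (0.12 log units; within the scatter), and chloro in place of hydrogen gives a 1.1-fold lower number from compound 2 to compound 4 (0.02 log units; within the scatter). The (4-chlorophenyl)sulfonyl group in place of hydrogen on the amine nitrogen in the ring gives a 1.1-fold higher number from compound 1 to compound 4 (0.02 log units; within the scatter), so all three sulfonyl compounds shown now stay within the scatter of the unsubstituted compound 1, and a change of this group at this carbon has yet to separate any pair. No measurement is available that bears on why these numbers do not separate.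

Going by these compounds, whether an amine or a carboxylic acid on the same aromatic carbon would step beyond the scatter remains open, since the groups read there so far are only nitro, chloro and hydrogen. On these data alone, it is also open whether a longer alkyl chain on the sulfonyl, in place of the aryl ring, would read any differently from the arylsulfonyl compounds on the same core.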